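Shifting the aryl group on a weak aminophenyl analogue

The source may hold more compounds than are shown below. What is called first, only, known or untested is meant among the compounds shown, and "the series" means these compounds.

Compound 1 `C=C(Br)C(=O)Nc1cccc(-c2cn3nc(-c4ccc(F)cc4)sc3n2)c1`: in a functional assay on L1210 cells (Mus musculus) for inhibition, read by cell counting, with a stated time of 2 days (a lower number here means a stronger inhibitor, a higher number a weaker inhibitor), compound 1 gives 250 nM.
Compound 2 `Nc1cccc(-c2cn3nc(CCc4ccccc4)sc3n2)c1`: in this assay compound 2 gives 31000 nM.
Compound 3 `COc1ccc(-c2csc3nc(-c4cccc(N)c4)cn23)cc1`: in this assay compound 3 gives 19000 nM.

Compound 2 holds the highest number of the three in this assay. Its nearest neighbour is compound 3, whose number sits within the scatter of compound 2, so the two cannot be ordered. Compound 1, which carries a bromoacrylamide on its aminophenyl position instead of a free amine, stands far away with a much lower number, beyond the scatter.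

Compound 4 `COc1cccc(Cc2nn3cc(-c4cccc(N)c4)nc3s2)c1` is not yet measured. It differs from compound 2 in one place: 3-methoxyphenyl in place of benzyl on a saturated chain carbon bound to an aromatic carbon. Going by the values given here, the free aniline and the shared core are kept, so the only change is in the pendant aryl group at the far end of the molecule.

Among the compounds with values here, no measured pair shows a step of this type, so there is nothing to scale the change against. Because compound 2 gives 31000 nM and compound 3, with a methoxyphenyl elsewhere on the core, gives 19000 nM, the expectation for compound 4 is a number in the same weak region. The step from compound 2 to compound 4 is expected to be a 1.2-fold lower number from compound 2 to compound 4 (0.09 log units; within the scatter), with no direction beyond the scatter. Compound 4 is estimated at 25000 nM in this assay, with a range from 8000 nM to 70000 nM.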

Compound 4, half-maximal inhibitory concentration: 21000 nM
Estimate against measurement, compound 4: 1.2-fold (0.08 log units) above, within the range that was stated.
By their numbers in this assay, from the lowest: compound 1; then compounds 3, 4 and 2 (each within the scatter of the next).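

In this assay, putting 3-methoxyphenyl in place of benzyl on a saturated chain carbon bound to an aromatic carbon gives a 1.5-fold lower number from compound 2 to compound 4 (0.17 log units; within the scatter). Going by these compounds alone, this is the first step that can be read at this position, and it lies within the scatter, so compound 2 and compound 4 cannot be ordered. The entering group brings an oxygen and a hydrogen-bond acceptor that benzyl lacks, yet with the free aniline and the shared core kept, compound 4 gives 21000 nM, and nothing available explains this result.

A single step cannot show whether this position tolerates every group or only these two aryl-bearing ones, and a carboxylic acid or a longer chain there might read differently. It also remains open what the bromoacrylamide carried by compound 1 would do in place of the free amine on the otherwise unchanged structure of compound 4, since no pair shown differs at that place alone.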